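Hydroxy added to the dibromo anilide

The compounds below may be only part of what the source reports. "The series", "measured", "known", "first", "only" and "open" are said of these compounds alone.

Compound 2 `O=C(Nc1ccccc1)c1cc(Br)cc(Br)c1` gives > 100000 nM in an assay on isolated protein for inhibition of thiosulfate sulfurtransferase (Homo sapiens), with a stated time of 60 min, in the absence of a further agent (a lower number here means a stronger inhibitor, a higher number a weaker inhibitor), a limit of the assay rather than a number. Compound 1 `O=C(Nc1ccccc1)c1cc(Br)ccc1O` likewise gives only a limit, > 100000 nM, in this assay. Compound 2 thus sits at the limit of > 100000 nM in this assay, at which 2 of the 2 values shown sit, with no measured number to order it against. Compound 3 `O=C(Nc1ccccc1)c1cc(Br)cc(Br)c1O` differs from compound 2 by hydroxy in place of hydrogen on an aromatic carbon. Within the data shown here, no measured step shows what this change does in this assay. Compound 1 carries the same hydroxy and also sits at the limit of > 100000 nM in this assay, at which 2 of the 2 values shown sit, so for compound 3 no step beyond the scatter is expected. Compound 3 is therefore expected at 150000 nM, between 50000 nM and 500000 nM, a step that the limit leaves unreadable from compound 2 to compound 3 that most likely again ends in a limit.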

Compound 3, half-maximal inhibitory concentration: > 100000 nM
Compound 3: a limit, no number; the forecaster's own chance of this, stated with the estimate: 85%; the middle value does not contradict the limit.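

Compound 3 gives > 100000 nM, a limit and not a number, so the steps to it from compound 1 and from compound 2 cannot be read. The compounds shown leave open which changes to the shared core, if any, would give a measurable value in this assay.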